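Aryl swap at the benzimidazole-linked phenyl: fluoro for methoxy

The compounds below may be only part of what the source reports. "The series", "measured", "known", "first", "only" and "open" are said of these compounds alone.

Three measured compounds share one core and differ only in the aromatic ring attached to it. Compound 1 `CC(=O)Nc1cccc(C2CCN(CCCn3c(-c4ccccc4C(F)(F)F)nc4ccccc43)CC2)c1` gives 50 nM in an assay for displacement of a labelled ligand from melanin-concentrating hormone receptor 1 (Homo sapiens), read by fluorescence; on this read-out lower numbers stand for stronger inhibition and higher numbers for weaker inhibition. Compound 2 `CC(=O)Nc1cccc(C2CCN(CCCn3c(-c4cccc(C(F)(F)F)c4)nc4ccccc43)CC2)c1` gives 30 nM, and a 1.7-fold lower number from compound 1 to compound 2 (0.22 log units; within the scatter). Compound 3 `COc1ccc(-c2nc3ccccc3n2CCCN2CCC(c3cccc(NC(C)=O)c3)CC2)cc1` gives 9 nM, the lowest of the three numbers; the gaps are a 5.6-fold lower number from compound 1 to compound 3 (0.74 log units; beyond the scatter) and a 3.3-fold lower number from compound 2 to compound 3 (0.52 log units; beyond the scatter), both beyond the scatter, so compound 3 stands apart from the other two.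

Compound 4 `CC(=O)Nc1cccc(C2CCN(CCCn3c(-c4ccc(F)cc4)nc4ccccc43)CC2)c1` has not been measured. It differs from compound 3 by fluoro in place of methoxy on an aromatic carbon. For the measured compounds named here, no measured step tests fluoro against methoxy directly. Going by the values given here, the steps that bear on it are the two leading into compound 3: both replace a trifluoromethyl-bearing phenyl with 4-methoxyphenyl and both lower the number by a modest amount, while the step from compound 1 to compound 2 shows that moving the trifluoromethyl group on the ring changed little. Removing the methoxy group and putting fluoro in its place is therefore expected to cost some of the gain seen in compound 3, with a step back toward the numbers of compounds 1 and 2 but probably not all the way. That amounts to an expected 2.8-fold higher number from compound 3 to compound 4 (0.44 log units; beyond the scatter). Compound 4 is estimated at 25 nM, with a range from 9 nM to 70 nM.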

Compound 4, half-maximal inhibitory concentration: 56 nM
Estimate against measurement, compound 4: 2.2-fold (0.35 log units) below; the range from low to high includes it.
By their numbers in this assay, from the lowest: compound 3; then compounds 2, 1 and 4 (each within the scatter of the next).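

The change of methoxy to fluoro, on an aromatic carbon para to a large group, gives a 6.2-fold higher number from compound 3 to compound 4 (0.79 log units; beyond the scatter) and removes the advantage that set compound 3 apart from the others. Compound 4 does not separate from the two trifluoromethyl-bearing compounds, with a 1.9-fold higher number from compound 2 to compound 4 (0.27 log units; within the scatter) and a 1.1-fold higher number from compound 1 to compound 4 (0.05 log units; within the scatter) both staying within the scatter, so a substituent at this place is not enough on its own: among the four rings shown, only 4-methoxyphenyl stands out, while 4-fluorophenyl, with its substituent at the same place, reads like the other two. Nothing on hand accounts for the difference between methoxy and fluoro at this place.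

The compounds shown leave open whether the low number of compound 3 is specific to methoxy or would also appear with an ethoxy, a hydroxyl or a dimethylamino group at the same place. They also leave open whether methoxy keeps that number when moved to another carbon of the ring, and whether an unsubstituted phenyl reads closer to compound 3 or to compound 4.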